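The source may hold more compounds than are shown below. What is called first, only, known or untested is meant among the compounds shown, and "the series" means these compounds.

Measured compounds:
compound 1, `CCOc1ccc(NC(=O)c2cccc(/C=C3\CC(=O)N(Cc4ccccc4)C3=O)c2)cc1`: 41700 nM
compound 2, `CCCCCN1C(=O)C/C(=C\c2cccc(C(=O)NCCCC)c2)C1=O`: > 100000 nM
compound 3, `Cc1ccc(NC(=O)c2cccc(/C=C3\CC(=O)N(c4ccccc4)C3=O)c2)cc1C`: > 100000 nM

In an ADME assay on HCT-116 cells (Homo sapiens) for cytotoxicity, read by MTT assay, with a stated time of 72 h (on this read-out higher numbers stand for weaker inhibition and lower numbers for stronger inhibition), compound 1 gives 41700 nM. Compound 2 returns no number in this assay but only a limit, > 100000 nM. Compound 3 likewise returns only a limit in this assay, > 100000 nM. Compound 3 therefore stands at the limit of > 100000 nM in this assay, at which 2 of the 3 values shown sit, and no value of its own is available to rank it against compound 1. Going by the values given here, no step between two measured compounds is available here, so the size of any change must be judged from the structures alone.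

Compound 4, `O=C(Nc1ccc(Cl)cc1)c1cccc(/C=C2\CC(=O)N(c3ccccc3)C2=O)c1`, differs from compound 3 in one place: 4-chlorophenyl in place of 3,4-dimethylphenyl on an amide-type nitrogen. The amide-type nitrogen and the rest of the shared core are untouched. Compound 4 is expected to show a step of an at least 1.1-fold lower number from compound 3 to compound 4 (0.04 log units; that floor lies within the scatter) in this assay, that is, no move beyond the usual scatter, in either direction. Compound 4 is estimated at 90000 nM in this assay, in a range from 25000 nM to 300000 nM, with a fair chance that this assay again reports only a limit.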

Compound 4, half-maximal inhibitory concentration: > 100000 nM
Compound 4 was reported as a limit; the forecaster's own chance of this, stated with the estimate: 60%; at least 1.1-fold (0.04 log units) between middle value and limit.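

Compound 3 and compound 4 both return only limits in this assay, so no step can be read between them: the limit of > 100000 nM in this assay, at which 3 of the 4 values shown sit.

The compounds shown leave open whether 4-chlorophenyl in place of 3,4-dimethylphenyl on an amide-type nitrogen changes this read-out at all.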